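Geometry change at one double bond, no comparable step measured

A few compounds are considered here, and "the series" means these few. Any claim that something is new, unique, unknown or untested is made for them only; others in the source may bear on it.

Of the compounds shown here, two have so far been measured in a functional assay on HCT-15 cells (Homo sapiens) for cytotoxicity; on this read-out lower numbers stand for an effect already at smaller amounts and higher numbers for an effect only at larger amounts of compound. Compound 1 `CC1=C(O)[C@@H](C/C(C)=C\CCC(C)/C=C/C/C(C)=C/CCc2ccoc2)OC1=O` gives 27.5 ug/mL. Compound 2 `CC1=C(O)/C(=C\[C@H](C)CCC/C(C)=C/CCc2coc(Cc3ccoc3)c2)OC1=O` gives 9.82 ug/mL, the lowest of the two numbers; compound 1 stands beyond the scatter above it. Compound 3 `CC1=C(O)/C(=C/[C@H](C)CCC/C(C)=C/CCc2coc(Cc3ccoc3)c2)OC1=O` is not yet measured. Its difference from compound 2: the two compounds have the same atoms and bonds and differ only in configuration as drawn: 1 of 3 stereo elements differ; a double bond is drawn E in compound 2 and Z in compound 3. Among the measured compounds shown here, no step between measured compounds shows the effect of such a change, so the direction stays open and no step beyond the scatter is expected. Compound 3 is therefore estimated at 12 ug/mL, with a range of 5 ug/mL to 30 ug/mL. This corresponds to an expected 1.2-fold higher number from compound 2 to compound 3 (0.09 log units; within the scatter).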

Compound 3, concentration for half-maximal effect: 6.91 ug/mL
Beside the measured number, compound 3's estimate is 1.7-fold (0.24 log units) above it; measured number inside the range.
By their numbers in this assay, from the lowest: compounds 3 and 2 (each within the scatter of the next); then compound 1.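

Among the compounds shown here, this is the first measured step at this double bond: in this assay, the change of geometry gives a 1.4-fold lower number from compound 2 to compound 3 (0.15 log units; within the scatter). Drawing the double bond Z rather than E therefore does not separate the two compounds on this read-out. The comparison isolates that single element, with nothing else altered: the fact that compounds 2 and 3 differ only in the configuration as drawn.

As far as these compounds go, whether the double bond's geometry stays equally silent when the rest of the molecule changes remains open. So does the outcome of placing a carboxylic acid or an amine on the furan-bearing chain, or of using a longer chain.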